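This account rests on a few compounds, and the source may have more. Where it says the series, first, only, none or still open, it means among the compounds named here.

Measured compounds:
Compound 1 `CCCCCCCCCCc1ccc(-c2noc(C3CNC3)n2)cc1`: 65%
Compound 2 `CCCCCCCCCCc1ccc(-c2noc(-c3cccc(CN)c3)n2)cc1`: 2%

For the measured compounds named here, in an assay on HeLa cells for inhibition of sphingosine-1-phosphate transporter SPNS2 (Mus musculus), read by LC-MS, tested at 2 uM (a higher number here means more inhibition at the concentration tested (going by the name of the read-out), a lower number less inhibition), compound 2 stands lowest of the two numbers; the one step measured, a number 63 percentage points lower from compound 1 to compound 2 (beyond the scatter), is large and beyond the scatter. Compound 3 `CCCCCCCCCCc1ccc(-c2noc(CC(O)CN)n2)cc1` differs from compound 2 by 3-amino-2-hydroxypropyl in place of 3-(aminomethyl)phenyl on an aromatic carbon. That step moves back from the aromatic group that brought the loss toward a small non-ring group carrying an amine, as in compound 1, so a gain is expected in this assay. For compound 3 the expected result is 40%, with a range from 10% to 70%. The expected step of a number 38 percentage points higher from compound 2 to compound 3 (beyond the scatter) is an estimate only, resting on compound 1 at 65%.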

Compound 3, a percentage reported as inhibition, at one concentration (the size of the read-out at that concentration, not a potency): 59%
Compound 3: the middle estimate sits 19 percentage points below what was measured; measured number inside the range.
By their numbers in this assay, from the lowest: compound 2; then compounds 3 and 1 (each within the scatter of the next).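

Swapping 3-(aminomethyl)phenyl for 3-amino-2-hydroxypropyl gives a number 57 percentage points higher from compound 2 to compound 3 (beyond the scatter) in this assay, so the loss seen with the aromatic group does not extend to every amine-bearing group on this aromatic carbon. The step of a number 6 percentage points lower from compound 1 to compound 3 (within the scatter) shows that, in this pair, the azetidin-3-yl ring can be replaced by a group with no ring. No measured evidence bears on the reason for either step.

On these data alone, whether the hydroxyl matters remains open, as 3-aminopropyl would test that directly. Also open, as far as these compounds go, is whether a carboxylic acid can stand in for the amine.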